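The source may hold more compounds than are shown below. What is called first, only, known or untested is meant among the compounds shown, and "the series" means these compounds.

Measured compounds:
- Compound 1, `Cc1cccc(Cc2nc3cc(O[C@H]4CC[C@@H](C(=O)O)CC4)ccc3n2C)c1`: 42 nM
- Compound 2, `Cn1c(Cc2cccc(C(F)(F)F)c2)nc2cc(O[C@H]3CC[C@@H](C(=O)O)CC3)ccc21`: 190 nM
- Compound 3, `Cn1c(Cc2cccc(C#N)c2)nc2cc(O[C@H]3CC[C@@H](C(=O)O)CC3)ccc21`: 51000 nM

All three share one core and differ only in the group on the pendant aromatic ring. In an assay on isolated protein for inhibition of Long-chain-fatty-acid--CoA ligase 1 (Homo sapiens), read by mass spectrometry, with a stated time of 90 min, in the presence of a further agent that is not named here (a higher number here means a weaker inhibitor, a lower number a stronger inhibitor), compound 1 gives 42 nM and compound 2 gives 190 nM; compound 3 gives 51000 nM, the highest number of the three. The steps to compound 3 are large in both cases: a 1200-fold higher number from compound 1 to compound 3 (3.08 log units; beyond the scatter) and a 270-fold higher number from compound 2 to compound 3 (2.43 log units; beyond the scatter), while a 4.5-fold higher number from compound 1 to compound 2 (0.66 log units; beyond the scatter) is only a modest step.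

Compound 4, `Cc1cccc(Oc2nc3cc(O[C@H]4CC[C@@H](C(=O)O)CC4)ccc3n2C)c1`, has not yet been tested. The change is 3-methylphenoxy in place of 3-cyanobenzyl on an aromatic carbon. For the measured compounds named here, it restores the methyl of compound 1, which the steps above show to be far better than the cyano, but it also swaps the single-carbon link for an oxygen, a change for which no measured step exists. Compound 4 is therefore expected to come well down from compound 3, giving an estimated 340-fold lower number from compound 3 to compound 4 (2.53 log units; beyond the scatter), landing near 150 nM with a wide range from 20 nM to 2000 nM to cover the unknown effect of the linker.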

Compound 4, half-maximal inhibitory concentration: 78000 nM
Estimate against measurement, compound 4: 520-fold (2.72 log units) below, outside the stated range (above it).
By their numbers in this assay, from the lowest: compound 1; then compound 2; then compounds 3 and 4 (each within the scatter of the next).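

In this assay, keeping the methyl on the pendant ring and changing only the link from carbon to oxygen is a large step, a 1900-fold higher number from compound 1 to compound 4 (3.27 log units; beyond the scatter), so at this position the linking atom matters, not just the group on the pendant ring. The gain seen for methyl over nitrile with the carbon link does not appear here: a 1.5-fold higher number from compound 3 to compound 4 (0.18 log units; within the scatter) lies within the scatter, so 3-methylphenoxy and 3-cyanobenzyl cannot be told apart in this assay. The data offer no measured explanation for the loss on moving to the oxygen link.

The compounds shown leave open whether an amine link or a longer chain would behave like the carbon link or like the oxygen link. They also leave open whether a trifluoromethyl or nitrile on the phenoxy ring would change the number at all.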